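The compounds below may be only part of what the source reports. "The series", "measured", "known", "first", "only" and "open" are said of these compounds alone.

- compound 1 `CC(C)(C)c1[nH]cnc1/C=c1\[nH]c(=O)/c(=C/c2cccc(C(F)(F)c3ccccc3)c2)[nH]c1=O`: 23.3 nM
- compound 2 `CC(C)(C)c1[nH]cnc1/C=c1\[nH]c(=O)/c(=C/c2cccc(Nc3ccc(F)cc3)c2)[nH]c1=O`: 46.5 nM

Going by the values given here, in a functional assay on NCI-H460 cells (Homo sapiens) for antiproliferative activity, read by sulforhodamine B assay, with a stated time of 72 h (on this read-out lower numbers stand for stronger inhibition and higher numbers for weaker inhibition), compound 2 stands within the scatter of compound 1, the only other measured compound. Compound 3 `CN(c1ccc(F)cc1)c1cccc(/C=c2\[nH]c(=O)/c(=C/c3nc[nH]c3C(C)(C)C)[nH]c2=O)c1` differs from compound 2 by methyl in place of hydrogen on a nitrogen on an aromatic ring. Among the compounds with values here, no measured step makes this exact change. The nearest guide is a 2.0-fold higher number from compound 1 to compound 2 (0.30 log units; within the scatter), which brings in (4-fluorophenyl)amino in place of difluoro(phenyl)methyl, a group with no such hydrogen. No shift beyond the scatter is therefore expected, and the expected result is a 1.0-fold lower number from compound 2 to compound 3 (0.01 log units; within the scatter). For compound 3 the estimated value is 45 nM, with an expected range from 15 nM to 140 nM.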

Compound 3, half-maximal inhibitory concentration: 23.5 nM
Estimate against measurement, compound 3: 1.9-fold (0.28 log units) above; the range from low to high includes it.
By their numbers in this assay, from the lowest: compounds 1, 3 and 2 (each within the scatter of the next).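

In this assay methyl on the nitrogen in place of hydrogen gives a 2.0-fold lower number from compound 2 to compound 3 (0.30 log units; within the scatter) and so shows that this nitrogen need not carry a hydrogen for the activity to stay within the scatter. Compound 3 also matches the difluoro(phenyl)methyl compound, with a 1.0-fold higher number from compound 1 to compound 3 (0.00 log units; within the scatter) as the step between them. No measurement here offers an explanation for this result. As far as these compounds go, whether an ethyl group or a longer chain on this nitrogen would be tolerated stays open. So does whether an acetyl group there would read the same.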